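The source may hold more compounds than are shown below. What is called first, only, known or untested is meant among the compounds shown, and "the series" means these compounds.

Two compounds share the core: compound 1 `O=C(CCCCCn1cc(Nc2ncc3ccn(Cc4ccccc4F)c3n2)cn1)NO` and compound 2 `O=C(CCCCCCn1cc(Nc2ncc3ccn(Cc4ccccc4F)c3n2)cn1)NO`. In an assay on isolated protein for inhibition of protein deacetylase HDAC6 (Homo sapiens), with a stated time of 60 min (on this read-out lower numbers stand for stronger inhibition and higher numbers for weaker inhibition), compound 1 gives 15.3 nM, and compound 2 gives 8.4 nM; the step of a 1.8-fold lower number from compound 1 to compound 2 (0.26 log units; within the scatter) concerns the chain only. Compound 2 holds the lower of the two numbers, with compound 1 nearest and within the scatter. Compound 3 `O=C(CCCCCCn1cc(Nc2ncc3ccn(C4CCCC4)c3n2)cn1)NO` differs by cyclopentyl in place of 2-fluorobenzyl on an aromatic nitrogen. Among the compounds with values here, no measured step touches this position, so the series gives no direction for it; only a modest step in this assay is expected, a 2.4-fold higher number from compound 2 to compound 3 (0.38 log units; beyond the scatter). Compound 3 is therefore estimated at 20 nM, within 5 nM to 80 nM.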

Compound 3, half-maximal inhibitory concentration: 22 nM
Estimate against measurement, compound 3: 1.1-fold (0.04 log units) below; measured number inside the range.
By their numbers in this assay, from the lowest: compounds 2, 1 and 3 (each within the scatter of the next, the first and the last beyond it).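

In this assay, within the data shown here, the first change at this position, cyclopentyl in place of 2-fluorobenzyl on an aromatic nitrogen, gives a 2.6-fold higher number from compound 2 to compound 3 (0.42 log units; beyond the scatter). The step is modest, so inhibition at this position does not depend on a six-membered aromatic ring or on fluorine. No measurement here offers a reason for the step. Among these compounds, the single pair does not separate the loss of fluorine from the change of ring, and a plain benzyl or a cyclohexyl on this nitrogen would address that. On these data alone, whether the step carries over to the shorter chain of compound 1 also remains open.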